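Adding a propyl group to compound 2

This account rests on a few compounds, and the source may have more. Where it says the series, first, only, none or still open, it means among the compounds named here.

Compound 1 `C=CCN(c1ccncc1)n1cccc1`: > 20 mg/kg
Compound 2 `Clc1cccn1Nc1ccncc1`: > 20 mg/kg

In a functional assay on the whole organism with Mus musculus as the target (on this read-out lower numbers stand for an effect already at smaller amounts and higher numbers for an effect only at larger amounts of compound), compound 2 reads > 20 mg/kg, which is a limit of the assay and not a number. Compound 1 reads > 20 mg/kg, and this too is a limit. Among the compounds with values here, the whole picture so far is the limit of > 20 mg/kg in this assay, at which 2 of the 2 values shown sit, so no measured step is available as a guide.

Compound 3 `CCCN(c1ccncc1)n1cccc1Cl` differs from compound 2 in a single place: propyl in place of hydrogen on a nitrogen on an aromatic ring.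

Going by these compounds, since compound 2 reads > 20 mg/kg, its true position is unknown, and any expectation for compound 3 is a rough one. A modest move towards smaller doses in this assay is expected, though compound 3 may well return only a limit again. The estimated change is an at least 1.3-fold lower number from compound 2 to compound 3 (0.12 log units; that floor lies within the scatter). For compound 3 the expected value is 15 mg/kg, with an estimated range from 4 mg/kg to 40 mg/kg.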

Compound 3, dose for half-maximal effect: > 20 mg/kg
Compound 3 ended at the assay's limit (the forecaster's own chance of this, stated with the estimate: 45%); at least 1.3-fold (0.12 log units) between middle value and limit.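

In this assay compound 3 gives > 20 mg/kg as a limit of the assay and not a number. Within the data shown here, compound 2 also reads only a limit, so no step between compound 2 and compound 3 can be read. All the compounds shown stop at the same point: the limit of > 20 mg/kg in this assay, at which 3 of the 3 values shown sit.

Going by these compounds, whether propyl in place of hydrogen on that nitrogen changes the dose needed, and in which direction, stays open.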